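From 4-methoxyphenyl to 3-methoxyphenyl: working notes on the series

The compounds below may be only part of what the source reports. "The series", "measured", "known", "first", "only" and "open" are said of these compounds alone.

For the measured compounds named here, in a functional assay on cells (Cancer cell lines, Homo sapiens) for inhibition, read by MTT assay, with a stated time of 48 h (a higher number here means a weaker inhibitor, a lower number a stronger inhibitor), compound 1 `O=C(/C=C/c1cccc(Cl)c1)NNC(=O)c1ccc2c(c1)OCCO2` gives 3560 nM and compound 2 `COc1ccc(/C=C/C(=O)NNC(=O)c2ccc3c(c2)OCCO3)cc1` gives 930 nM as the lower of the two numbers so far. Compound 3 `COc1cccc(/C=C/C(=O)NNC(=O)c2ccc3c(c2)OCCO3)c1` keeps the shared core and carries 3-methoxyphenyl in place of 4-methoxyphenyl on a double-bonded chain carbon bound to a double-bonded chain carbon. Going by the values given here, only one measured step bears on this change. It is a 3.8-fold lower number from compound 1 to compound 2 (0.58 log units; beyond the scatter) and it helps only in part, since it swaps 3-chlorophenyl for 4-methoxyphenyl and so alters the group and its place together. Among the compounds with values here, these two compounds cannot separate those contributions, and no measured pair isolates the place of the methoxy group. A move towards the higher number of compound 1 is therefore expected, but smaller than the measured step, and it may stay within the scatter. The estimated step is a 1.8-fold higher number from compound 2 to compound 3 (0.26 log units; within the scatter) in this assay as a working figure. For compound 3 the estimated value is 1700 nM with an expected range from 650 nM to 4500 nM in this series.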

Compound 3, half-maximal inhibitory concentration: 170 nM
Beside the measured number, compound 3's estimate is 10-fold (1.00 log units) above it; measured number below the stated range.
By their numbers in this assay, from the lowest: compound 3; then compound 2; then compound 1.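

The shift of the methoxy group alone, with the same atoms joined differently, gives a 5.5-fold lower number from compound 2 to compound 3 (0.74 log units; beyond the scatter) in this assay, so the place of the group on the aromatic ring matters in its own right, which the earlier pair could not show. With the place held, methoxy in place of chloro on an aromatic carbon gives a 21-fold lower number from compound 1 to compound 3 (1.32 log units; beyond the scatter), so the group matters as well, and the earlier 3.8-fold lower number from compound 1 to compound 2 (0.58 log units; beyond the scatter) is now seen as the net of a change of group and a change of place that pull in opposite directions in this assay. No measurement on these compounds accounts for either step.

As far as these compounds go, what 4-chlorophenyl gives on the same chain carbon stays open, and with it whether the place of the group matters as much for chloro as for methoxy. Also open, from the compounds shown here alone, is whether an amine, a carboxylic acid or a longer ether chain carried on the aromatic ring in the same place as the methoxy group of 3-methoxyphenyl would keep the low number of compound 3 at 170 nM.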